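Swapping a butylphenyl for a methoxyphenyl carbonyl

This account rests on a few compounds, and the source may have more. Where it says the series, first, only, none or still open, it means among the compounds named here.

Compound 1 `CCCCCCCCS(=O)(=O)Nc1cc(-c2ccc(-c3ccccc3)cc2)ccc1C(=O)O`: 13500 nM
Compound 2 `CCCCCCCCS(=O)(=O)Nc1cc(-c2ccccc2O)ccc1C(=O)O`: 63100 nM
Compound 3 `CCCCCCCCS(=O)(=O)Nc1ccc(-c2ccc(CCCC)cc2)cc1C(=O)O`: 9000 nM

All three were tested in an assay on mitochondria (strain BALB/c) for inhibition of glycerol-3-phosphate acyltransferase 1, mitochondrial (Mus musculus), read by scintillation counting, with a stated time of 10 min; on this read-out higher numbers stand for weaker inhibition and lower numbers for stronger inhibition. Compound 3 gives the lowest of the three numbers; compound 1 sits close to it, within the scatter, while compound 2 sits well beyond the scatter at a higher number. Compound 4 `CCCCCCCCS(=O)(=O)Nc1ccc(C(=O)c2ccc(OC)cc2)cc1C(=O)O` has not yet been measured. It differs from compound 3 in a single place: (4-methoxyphenyl)carbonyl in place of 4-butylphenyl on an aromatic carbon. Going by the values given here, no measured pair shows a change of this kind, so the expectation rests on the spread seen so far. A modest move toward a higher number is expected, a 2.2-fold higher number from compound 3 to compound 4 (0.35 log units; beyond the scatter), probably just beyond the scatter. Compound 4 is therefore estimated at 20000 nM, within a range from 7000 nM to 60000 nM in this assay.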

Compound 4, half-maximal inhibitory concentration: 44300 nM
For compound 4 the middle estimate is 2.2-fold (0.35 log units) below the measured one, and the stated range covers the measured number.
By their numbers in this assay, from the lowest: compounds 3 and 1 (each within the scatter of the next); then compounds 4 and 2 (each within the scatter of the next).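

In this assay, going by these compounds alone, the change from 4-butylphenyl to (4-methoxyphenyl)carbonyl at this position gives a 4.9-fold higher number from compound 3 to compound 4 (0.69 log units; beyond the scatter), the first single-place step. The two groups hold the same number of heavy atoms, so this step comes with no change in that count, only with a carbonyl and a methoxy oxygen entering as hydrogen-bond acceptors. No measurement here says why the number rises. Whether the carbonyl or the methoxy group accounts for the step remains open, as a plain benzoyl or a 4-methoxyphenyl group would help to show. Going by these compounds, how an amine or a longer alkyl chain would behave at this position is also open.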